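Sulfur-linked heterocycle swaps on the dicyano-aminopyridine series

The source may hold more compounds than are shown below. What is called first, only, known or untested is meant among the compounds shown, and "the series" means these compounds.

Compound 1 `N#Cc1c(N)nc(SCc2ccn[nH]2)c(C#N)c1-c1ccc(OCC2CC2)cc1` and compound 2 `N#Cc1c(N)nc(SCC2=NCCN2)c(C#N)c1-c1ccc(OCC2CC2)cc1` share the core and differ only in the ring carried on a saturated chain carbon bound to a sulfur. In an assay on CHO cells for displacement of a labelled ligand from adenosine receptor A1 (Homo sapiens), read by scintillation counting, with a stated time of 90 min (on this read-out higher numbers stand for weaker inhibition and lower numbers for stronger inhibition), compound 1 gives 552 nM and compound 2 gives 483 nM; the step of a 1.1-fold lower number from compound 1 to compound 2 (0.06 log units; within the scatter) shows that the swap of one five-membered ring for another left the number essentially unchanged. Compound 2 therefore stands lowest of the two numbers, with compound 1 within the scatter of it. Compound 3 `N#Cc1c(N)nc(SCc2csc(N)n2)c(C#N)c1-c1ccc(OCC2CC2)cc1` carries the change (a group of 6 heavy atoms (3 carbon, 2 nitrogen, 1 sulfur; one five-membered aromatic ring with 2 hetero atoms) in place of a group of 5 heavy atoms (3 carbon, 2 nitrogen; one five-membered non-aromatic ring with 2 hetero atoms), on a saturated chain carbon bound to a sulfur). Among the compounds with values here, the one step that bears on it, from compound 1 to compound 2, was within the scatter, so no step beyond the scatter is expected in this assay; the expected step of a 1.0-fold higher number from compound 2 to compound 3 (0.02 log units; within the scatter) is small. Compound 3 is estimated at 500 nM, with a range from 250 nM to 1000 nM.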

Compound 3, inhibition constant: 140 nM
Beside the measured number, compound 3's estimate is 3.6-fold (0.55 log units) above it; measured number outside the range, below it.
By their numbers in this assay, from the lowest: compound 3; then compounds 2 and 1 (each within the scatter of the next).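

In this assay, the ring on a saturated chain carbon bound to a sulfur can move the number: 2-amino-1,3-thiazol-4-yl gives a 3.5-fold lower number from compound 2 to compound 3 (0.54 log units; beyond the scatter), and in place of 1H-pyrazol-5-yl it gives a 3.9-fold lower number from compound 1 to compound 3 (0.60 log units; beyond the scatter). The earlier pair of rings showed no step beyond the scatter, so not every five-membered ring swap at this position leaves the number in place.

From the compounds shown here alone, how a 1,3-thiazol-4-yl group without the amine, or with a methyl group in place of the amine, would read remains open. No measurement here accounts for the step.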